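Swapping a furan for a fluorinated methoxyphenyl group

The source may hold more compounds than are shown below. What is called first, only, known or untested is meant among the compounds shown, and "the series" means these compounds.

Of the compounds shown here, three sharing one core have been measured in a physicochemical assay for solubility, with a stated time of 18 h, at pH 7.4; a lower number here means a less soluble compound, a higher number a more soluble compound. Compound 1 `COc1ccc(F)cc1CNCCCNc1ccnc2cc(Cc3cc(C)cc(C)c3)ccc12` gives 4200 nM, and compound 2 `COc1ccc(F)cc1CNCCCNc1ccnc2cc(CCc3ccccc3)ccc12` gives 4200 nM. The step of no change at the digits printed from compound 1 to compound 2 (within the scatter) shows that this exchange on the other side of the molecule left the number where it was. Compound 3 `CN(C)c1cccc(Oc2ccc3c(NCCCNCc4ccco4)ccnc3c2)c1` stands highest of the three, giving 14500 nM; its distance to both compound 1 and compound 2 is beyond the scatter.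

The next compound, compound 4 `COc1ccc(F)cc1CNCCCNc1ccnc2cc(Oc3cccc(N(C)C)c3)ccc12`, keeps everything of compound 3 except one group: 5-fluoro-2-methoxyphenyl in place of furan-2-yl on a saturated chain carbon bound to an amine nitrogen. Among the compounds with values here, no measured step covers this exact exchange. Within the data shown here, the only measured step, from compound 1 to compound 2, concerns a different part of the molecule and says nothing about it. What can be noted is that compound 1 and compound 2 both already carry the entering group and sit lower than compound 3, yet they also differ from compound 3 elsewhere, so that gap cannot be assigned to the group alone.

On this basis the expectation for compound 4 is a modest fall from compound 3, a 2.1-fold lower number from compound 3 to compound 4 (0.32 log units; beyond the scatter), though a result within the scatter would not surprise. Compound 4 is therefore estimated at 7000 nM, with a range from 3000 nM to 16000 nM.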

Compound 4, solubility: 14500 nM
Estimate against measurement, compound 4: 2.1-fold (0.32 log units) below; measured number inside the range.
By their numbers in this assay, from the lowest: compounds 1 and 2 (each within the scatter of the next); then compounds 3 and 4 (each within the scatter of the next).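

In this assay, within the data shown here, the first exchange that can be read on the saturated chain carbon bound to an amine nitrogen replaces furan-2-yl with the larger 5-fluoro-2-methoxyphenyl, and it gives no change at the digits printed from compound 3 to compound 4 (within the scatter). With 5-fluoro-2-methoxyphenyl held in place, the other side of the molecule does make a difference: 3-(dimethylamino)phenoxy in place of phenethyl on an aromatic carbon gives a 3.5-fold higher number from compound 2 to compound 4 (0.54 log units; beyond the scatter), and 3-(dimethylamino)phenoxy in place of 3,5-dimethylbenzyl on an aromatic carbon gives a 3.5-fold higher number from compound 1 to compound 4 (0.54 log units; beyond the scatter). Among these steps, then, the number moves with the exchanges on the aromatic carbon and stays put with the exchange on the chain carbon, though nothing available explains either outcome.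

From the compounds shown here alone, it remains open whether this tolerance on the chain carbon extends to other groups, such as a pyridine ring or a carboxylic acid. Going by these compounds, it is also open which part of 3-(dimethylamino)phenoxy goes with the higher number, and a plain phenoxy group would be the comparison that separates the ring from its dimethylamino group.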